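A few compounds are considered here, and "the series" means these few. Any claim that something is new, unique, unknown or untested is made for them only; others in the source may bear on it.

Compound 1 `CC(=O)/C(C)=C/c1ccc([N+](=O)[O-])cc1`: 266000 nM
Compound 2 `C/C(=C\c1ccccc1)C(=O)/C=C/c1ccccc1`: 33600 nM

Both compounds were tested in an ADME assay on LLC-MK2 cells (Macaca mulatta) for cytotoxicity, read by MTT assay, with a stated time of 48 h; a higher number here means that more compound is tolerated, a lower number that less compound is tolerated. Of the two numbers, the lower belongs to compound 2, at 33600 nM. The higher belongs to compound 1, at 266000 nM. The gap between these two numbers lies beyond the scatter, so compound 2 is the less tolerated of the pair.

The next compound to be measured is compound 3 `COc1ccc(/C=C/C(=O)/C(C)=C/c2ccccc2)cc1`. It differs from compound 2 in one place: methoxy in place of hydrogen on an aromatic carbon. In words, methoxy stands in place of hydrogen on an aromatic carbon of a six-membered aromatic ring of carbon only, para to a large group.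

For the measured compounds named here, the data hold no measured pair that shows this change on its own, so any expectation for it is loose. With nothing to set a direction, no step beyond the scatter is expected in this assay, though a larger move in either direction cannot be ruled out. The expected result is a 1.1-fold lower number from compound 2 to compound 3 (0.05 log units; within the scatter). For compound 3 the estimated value is 30000 nM, with an expected range of 11000 nM to 85000 nM.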

Compound 3, half-maximal cytotoxic concentration: 93000 nM
Compound 3: the middle estimate sits 3.1-fold (0.49 log units) below what was measured, and the stated range ends below it.
By their numbers in this assay, from the lowest: compound 2; then compound 3; then compound 1.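

The methoxy group, on an aromatic carbon para to a large group, brings a 2.8-fold higher number from compound 2 to compound 3 (0.44 log units; beyond the scatter) in this assay and so shows that this place on the six-membered aromatic ring is not silent in this assay. Adding a group there moves the number beyond the scatter, and the move is toward more compound being tolerated, not less. The step is modest and comes from a single pair, so it describes methoxy in place of hydrogen on this one core and sets no rule for the position, and nothing available explains why the number rises with this change.

The compounds shown leave open whether the rise belongs to methoxy itself or would follow from other groups at the same carbon, such as a hydroxyl group, a chlorine atom or an amine. They also leave open whether a longer chain on the same oxygen would carry the number further in the same direction, or whether the step would hold on a different core.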